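Trifluoromethyl to cyano: will the limit hold?

The source may hold more compounds than are shown below. What is called first, only, known or untested is meant among the compounds shown, and "the series" means these compounds.

In an ADME assay on HaCaT cells (Homo sapiens) for antiproliferative activity, with a stated time of 48 h (on this read-out higher numbers stand for weaker inhibition and lower numbers for stronger inhibition), compound 1 (`CCN(CC)c1ccc(-c2cccc(OC)c2)nn1`) gives > 25000 nM as a limit of the assay, not a number. Compound 2 (`CCN(CC)c1ccc(-c2cccc(C(F)(F)F)c2)nn1`) gives > 25000 nM and this too is only a limit. Compound 2 therefore has no exact value and stands at the limit of > 25000 nM in this assay, at which 2 of the 2 values shown sit. Going by the values given here, the one measured step is a step that the two limits leave unreadable from compound 1 to compound 2 (trifluoromethyl in place of methoxy), so it offers no size to carry forward.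

Compound 3 (`CCN(CC)c1ccc(-c2cccc(C#N)c2)nn1`) differs from compound 2 in a single group: cyano in place of trifluoromethyl on an aromatic carbon. The swap sits on an aromatic carbon, meta to a large group. This expectation rests on both earlier compounds sitting at the limit of > 25000 nM in this assay, at which 2 of the 2 values shown sit: no step beyond the scatter is expected in this assay, and another limit is the likeliest result. The expected step is a step that the limit leaves unreadable from compound 2 to compound 3. The estimate for compound 3 is 30000 nM (estimated range 12000 nM to 50000 nM).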

Compound 3, half-maximal inhibitory concentration: > 25000 nM
Compound 3: no number, only a limit; the forecaster's own chance of this, stated with the estimate: 80%; the middle value is on the limit's open side.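

Going by these compounds alone, compound 1, compound 2 and compound 3 each give only a limit of the assay, not a number, so no step between them can be read: the limit of > 25000 nM in this assay, at which 3 of the 3 values shown sit. The compounds shown leave open whether methoxy, trifluoromethyl and cyano differ at all in this read-out.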